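Halogenated aryl ester series: tolerance in T cells

This account rests on a few compounds, and the source may have more. Where it says the series, first, only, none or still open, it means among the compounds named here.

The compounds share one core and differ only in the halogenated aryl ester. Compound 1 `COC(=O)c1cc(Cl)ccc1OC(=O)COc1cc(O)c2c(=O)cc(-c3ccccc3)oc2c1` gives in an ADME assay on cells (T-cell, Mus musculus, strain BALB/c) for cytotoxicity, read by MTT assay, with a stated time of 48 h (a lower number here means that less compound is tolerated, a higher number that more compound is tolerated), only a limit of the assay, > 436000 nM. Compound 2 `COC(=O)c1c(Br)cccc1OC(=O)COc1cc(O)c2c(=O)cc(-c3ccccc3)oc2c1` gives in this assay 388000 nM. Compound 3 `COC(=O)c1cc(Br)ccc1OC(=O)COc1cc(O)c2c(=O)cc(-c3ccccc3)oc2c1` gives in this assay likewise only a limit of the assay, > 450000 nM. Compound 3 therefore stands at the edge of what the assay reports, and a second value in the set is also a limit. Among the measured compounds shown here, the steps that bear on the next change are an at least 1.1-fold higher number from compound 2 to compound 3 (0.06 log units; that floor lies within the scatter), an at least 1.1-fold lower number from compound 1 to compound 2 (0.05 log units; that floor lies within the scatter) and a step that the two limits leave unreadable from compound 1 to compound 3. Compound 4 `COC(=O)c1c(Cl)cccc1OC(=O)COc1cc(O)c2c(=O)cc(-c3ccccc3)oc2c1` differs from compound 3 by 3-chloro-2-(methoxycarbonyl)phenyl in place of 4-bromo-2-(methoxycarbonyl)phenyl on an oxygen next to a carbonyl group. On these steps no change beyond the scatter is expected, an at least 1.1-fold lower number from compound 3 to compound 4 (0.05 log units; that floor lies within the scatter). Compound 4 is expected to give about 400000 nM, within 250000 nM to 500000 nM.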

Compound 4, half-maximal cytotoxic concentration: 366000 nM
Estimate against measurement, compound 4: 1.1-fold (0.04 log units) above; measured number inside the range.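

In this assay, among the compounds shown here, the exchange of chloro for bromo on an aromatic carbon can now be read between two actual numbers for the first time, and it gives a 1.1-fold lower number from compound 2 to compound 4 (0.03 log units; within the scatter). The other two steps, an at least 1.2-fold lower number from compound 3 to compound 4 (0.08 log units; that floor lies within the scatter) and an at least 1.1-fold lower number from compound 1 to compound 4 (0.07 log units; that floor lies within the scatter), each start from a limit of the assay and give only a floor. Across these steps, the aryl ester exchanges shown produce no change beyond the scatter. On these data alone, the true size of the steps from the two limits stays open, and so does the effect of an amine or a carboxylic acid in place of the methoxycarbonyl group.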